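This account rests on a few compounds, and the source may have more. Where it says the series, first, only, none or still open, it means among the compounds named here.

Series notes in an assay on membranes from CHO cells for displacement of a labelled ligand from adenosine receptor A1 (Homo sapiens), read by scintillation counting, with a stated time of 60 min, tested at 1 uM; a lower number here means less inhibition, a higher number more inhibition at the concentration tested (going by the name of the read-out). Compound 3 `CC1=C(C(=O)OC2CCCC2)C(c2cccs2)NC(=O)N1` gives 9% in this assay. Compound 1 `CCNC(=O)C1=C(C)NC(=O)NC1c1cccs1` gives 1%, and compound 2 `CC1=C(C(=O)OC2CCCCC2)C(c2ccco2)NC(=O)N1` gives 1%. All three numbers sit within the usual scatter of one another, so compound 3 cannot be set apart from compound 1 or from compound 2 on these readings. Going by the values given here, the single one-place step available, a number 8 percentage points higher from compound 1 to compound 3 (within the scatter), does not move beyond the scatter either.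

Compound 4 `CC1=C(C(=O)OC2CCCCC2)C(c2cccs2)NC(=O)N1` differs from compound 3 in one place: cyclohexyl in place of cyclopentyl on an oxygen next to a carbonyl group. Among the compounds with values here, no measured pair in the set isolates this exchange of cyclopentyl for cyclohexyl on its own. Compound 2 carries the cyclohexyl ester but differs from compound 4 elsewhere as well, so its value and that of compound 3 can only be placed side by side, where they also fall within the scatter. The step of a number 8 percentage points higher from compound 1 to compound 3 (within the scatter) changes the whole group on the carbonyl carbon and bears on the ester position only loosely. With every recorded number low and no step beyond the scatter, compound 4 is expected to show no change beyond the scatter, a number 4 percentage points lower from compound 3 to compound 4 (within the scatter). Compound 4 is therefore estimated at 5%, with a range from -4% to 15%.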

Compound 4, a percentage reported as inhibition, at one concentration (the size of the read-out at that concentration, not a potency): 7%
The estimate for compound 4 lay 2 percentage points below the measured number, and the stated range covers the measured number.
By their numbers in this assay, from the lowest: compounds 1, 2, 4 and 3 (each within the scatter of the next).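

In this assay, the exchange of cyclopentyl for cyclohexyl on an oxygen next to a carbonyl group can now be read on its own, as a number 2 percentage points lower from compound 3 to compound 4 (within the scatter), so this change of ring size on the ester shows no effect that can be separated from the scatter. Two other places also gain a one-place reading: thiophen-2-yl in place of furan-2-yl on a saturated ring carbon gives a number 6 percentage points higher from compound 2 to compound 4 (within the scatter), and changing the group on the carbonyl carbon gives a number 6 percentage points higher from compound 1 to compound 4 (within the scatter), which now tests that exchange with the cyclohexyl ester as well as the cyclopentyl ester, again without a step beyond the scatter. No supporting data bear on why these readings stay so close together.

Going by these compounds, whether a carboxylic acid or a longer chain on the same carbonyl carbon, or a phenyl group in place of thiophen-2-yl, would give a step beyond the scatter remains open. The read-out is a size at a single concentration, so the potency of these compounds and any differences in potency among them also remain open.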